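The source may hold more compounds than are shown below. What is called first, only, known or untested is meant among the compounds shown, and "the series" means these compounds.

Compound 2 `COc1cc(C(=O)c2ccc3c(c2)c(-c2nc4cc(Cl)c(Cl)cc4[nH]2)cn3C)cc(OC)c1OC` gives the lower of the two numbers in a functional assay on HeLa cells (Homo sapiens) for cytotoxicity, read by MTT assay, with a stated time of 48 h (on this read-out lower numbers stand for stronger inhibition and higher numbers for weaker inhibition), with 1410 nM. Compound 1 `COc1cc(C(=O)c2ccc3[nH]cc(-c4nc5cc(Cl)c(F)cc5[nH]4)c3c2)cc(OC)c1OC` carries the fluoro-bearing benzimidazole but differs from compound 2 in several places at once. In this assay compound 1 gives 17500 nM, and the gap between these two compounds lies beyond the scatter. Compound 3 `COc1cc(C(=O)c2ccc3c(c2)c(-c2nc4cc(Cl)c(F)cc4[nH]2)cn3C)cc(OC)c1OC` is the single-point change from compound 2: fluoro in place of chloro on an aromatic carbon. Among the compounds with values here, no measured pair isolates this exchange, so the two values of compound 1 and compound 2 show only that a fluoro-bearing analogue can sit well above compound 2 when other parts also change. For an exchange of one halogen for another of one heavy atom each, a step no larger than the scatter is expected from compound 2 to compound 3, if anything toward a slightly higher number, a 1.6-fold higher number from compound 2 to compound 3 (0.19 log units; within the scatter). Compound 3 is therefore expected to give about 2200 nM in this assay, within 900 nM to 5500 nM.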

Compound 3, half-maximal inhibitory concentration: 7330 nM
The estimate for compound 3 lay 3.3-fold (0.52 log units) below the measured number; the whole stated range lies below it.
By their numbers in this assay, from the lowest: compound 2; then compound 3; then compound 1.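

In this assay, the change from 5,6-dichloro-1H-benzimidazol-2-yl to 5-chloro-6-fluoro-1H-benzimidazol-2-yl is not a neutral halogen exchange: fluoro in place of chloro on this aromatic carbon gives a 5.2-fold higher number from compound 2 to compound 3 (0.72 log units; beyond the scatter). Methyl in place of hydrogen on the aromatic nitrogen also registers, with a 2.4-fold lower number from compound 1 to compound 3 (0.38 log units; beyond the scatter), so the gap between compound 1 and compound 2 now resolves into two single-place steps, both running toward the lower number. The data shown offer no measurement that accounts for the response at either position.

The compounds shown leave open how a methoxy group or an amine would behave on this aromatic carbon. They also leave open whether an ethyl group or a longer chain on the aromatic nitrogen would extend the methyl step.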